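Aryl swap on the sulfonamide of the shared core

The source may hold more compounds than are shown below. What is called first, only, known or untested is meant among the compounds shown, and "the series" means these compounds.

Within the data shown here, compound 2 `Cc1ccc(S(=O)(=O)N(C)c2ccc3[nH]c(-c4n[nH]c5ccccc45)cc3n2)cc1` gives 27100 nM in a functional assay on A549 cells (Homo sapiens) for antiproliferative activity, read by MTT assay, with a stated time of 72 h (a lower number here means a stronger inhibitor, a higher number a weaker inhibitor), the highest of the two numbers so far; compound 1 `COc1ccc(C(=O)N(C)c2ccc3[nH]c(-c4n[nH]c5ccccc45)cc3n2)cc1` gives 14600 nM, and the step of a 1.9-fold higher number from compound 1 to compound 2 (0.27 log units; within the scatter) lies within the scatter. Compound 3 `COc1ccc(S(=O)(=O)N(C)c2ccc3[nH]c(-c4n[nH]c5ccccc45)cc3n2)c(OC)c1` differs from compound 2 by 2,4-dimethoxyphenyl in place of 4-methylphenyl on a sulfonyl sulfur. Among the measured compounds shown here, no measured step alters the group on the sulfonyl sulfur; the only known step concerns the group on the ring nitrogen and is itself within the scatter, so nothing bears directly on this change. The step of a 1.1-fold lower number from compound 2 to compound 3 (0.04 log units; within the scatter) is therefore expected to stay within the scatter. Compound 3 is estimated at 25000 nM, range 8000 nM to 80000 nM.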

Compound 3, half-maximal inhibitory concentration: 25900 nM
Compound 3: the middle estimate sits 1.0-fold (0.02 log units) below what was measured, within the range that was stated.
By their numbers in this assay, from the lowest: compounds 1, 3 and 2 (each within the scatter of the next).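

Among these compounds, on the sulfonyl sulfur, the only aryl change measured so far, 2,4-dimethoxyphenyl in place of 4-methylphenyl, gives a 1.0-fold lower number from compound 2 to compound 3 (0.02 log units; within the scatter) in this assay. Compound 3 reads 25900 nM in that assay, so adding the two methoxy groups and removing the methyl group leaves no readable difference at this position. No measurement at hand explains this result. Still open, as far as these compounds go, is whether an amine or a carboxylic acid on this aryl ring, or a straight alkyl chain replacing the ring, would move the number beyond the scatter.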